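The source may hold more compounds than are shown below. What is called first, only, known or untested is meant among the compounds shown, and "the series" means these compounds.

Measured compounds:
compound 1, `Cc1cc2cc(NS(=O)(=O)c3cc(C(=O)NO)ccc3Cl)ccc2n(C)c1=O`, 59%
compound 2, `Cc1cc2cc(NCc3cc(C(=O)NO)ccc3Cl)ccc2n(C)c1=O`, 84%
compound 3, `COc1ccc(C(=O)NO)cc1CS(=O)(=O)Nc1ccc2c(c1)cc(C)c(=O)n2C`, 63%

All three were tested in an assay on isolated protein for inhibition of protein deacetylase HDAC6 (Homo sapiens), read by fluorescence, with a stated time of 90 min, tested at 10 uM; a lower number here means a weaker effect, a higher number a stronger effect of the compound at the concentration tested. Among the three numbers, compound 3 stands second highest. Its nearest neighbour is compound 1, whose number is lower by an amount that falls within the usual scatter of repeated measurements, so the two cannot be told apart. The furthest is compound 2, whose number lies higher by an amount beyond that scatter.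

The step of interest leads from compound 3 to compound 4, `Cc1cc2cc(NS(=O)(=O)Cc3cccc(C(=O)NO)c3)ccc2n(C)c1=O`, which has not yet been tested in this assay. Compound 4 differs from compound 3 in one place: hydrogen in place of methoxy on an aromatic carbon. The methoxy sits ortho to a large group and para to the hydroxycarbamoyl group, and in compound 4 only a hydrogen atom remains there.

For the measured compounds named here, no pair of measured compounds differs by this change alone, so nothing measured here shows what removing the methoxy does. Without such a guide, the expectation is a step from compound 3 to compound 4 that stays within the usual scatter, in no firm direction: a number 3 percentage points lower from compound 3 to compound 4 (within the scatter). On that basis compound 4 is estimated to give 60% in this assay, with a plausible range from 40% to 78%.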

Compound 4, a percentage reported as inhibition, at one concentration (the size of the read-out at that concentration, not a potency): 33%
Beside the measured number, compound 4's estimate is 27 percentage points above it; measured number below the stated range.
By their numbers in this assay, from the lowest: compound 4; then compounds 1 and 3 (each within the scatter of the next); then compound 2.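

Replacing the methoxy with a hydrogen on this aromatic carbon, ortho to a large group and para to a hydroxycarbamoyl group, gives a number 30 percentage points lower from compound 3 to compound 4 (beyond the scatter) in this assay. For the compounds shown here, this pair provides the first direct reading of the position, and it shows that the position is not indifferent to what it carries: in this core, the compound with methoxy has the stronger effect at the concentration tested. Nothing available explains the drop.

As far as these compounds go, with only methoxy and hydrogen to compare here, it remains open whether an ethoxy, a hydroxyl, a fluorine or a chlorine at the same carbon would keep the number of compound 3, exceed it or fall towards that of compound 4. From the compounds shown here alone, it is also open whether removing the methoxy would produce a similar step with a different connection to the shared core, and because each number comes from a single concentration, the step describes the size of the read-out rather than a change in potency.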